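This account rests on a few compounds, and the source may have more. Where it says the series, first, only, none or still open, it means among the compounds named here.

Three close relatives of one chlorinated purine-like core have been tested in a functional assay on MCF7 cells (Homo sapiens) for cytotoxicity, read by sulforhodamine B assay, with a stated time of 48 h; a higher number here means a weaker inhibitor of growth, a lower number a stronger inhibitor of growth. Compound 1, `ClCc1ccccc1Cn1cnc2c(Cl)nc(Cl)nc21`, gives 810 nM. Compound 2, `ClCc1cccc(Cn2cnc3c(Cl)nc(Cl)nc32)c1`, carries the same atoms joined differently; the difference between the two cores is not broken down here, and compound 2 gives 2040 nM. Compound 3, `Nc1nc(Cl)c2ncn(Cc3ccccc3CCl)c2n1`, is compound 1 with amino in place of chloro on an aromatic carbon, and compound 3 gives 6030 nM. That change weakened growth inhibition: a 7.4-fold higher number from compound 1 to compound 3 (0.87 log units; beyond the scatter).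

Compound 4, `Nc1nc(Cl)c2ncn(Cc3cccc(CCl)c3)c2n1`, is not yet measured. It stands to compound 2 as compound 3 stands to compound 1, with amino in place of chloro on an aromatic carbon at an identically described place, so it is the same change.

In this assay the step is expected to be a 6.4-fold higher number from compound 2 to compound 4 (0.80 log units; beyond the scatter). That expectation rests on the measured step of a 7.4-fold higher number from compound 1 to compound 3 (0.87 log units; beyond the scatter), the only example of this change among these compounds, so a single precedent carries it. Compound 4 is therefore expected to give about 13000 nM in this assay, most likely between 5000 nM and 35000 nM.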

Compound 4, concentration for 50% growth inhibition: 2390 nM
Estimate against measurement, compound 4: 5.4-fold (0.74 log units) above; measured number outside the range, below it.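

In this assay, amino in place of chloro on an aromatic carbon gave a 1.2-fold higher number from compound 2 to compound 4 (0.07 log units; within the scatter), so on this core the swap made no clear difference to growth inhibition, unlike on the core of compound 1. Set side by side, the two examples disagree: the same change on two cores in this assay, a 7.4-fold higher number (0.87 log units; beyond the scatter) from compound 1 to compound 3 and a 1.2-fold higher number (0.07 log units; within the scatter) from compound 2 to compound 4, 6.4-fold (0.80 log units) apart, beyond the scatter of two such steps. This shows that, in this series, the size of the step did not carry from one core to the other, but two pairs cannot show why they part or how the change would behave on any further core.

From the compounds shown here alone, only chloro and amino appear at this place, so it remains open whether a methylamino or methoxy group there would also give steps that differ between the two cores. Going by these compounds, it is also open whether the split stays when the chloromethyl group on the benzyl ring gives way to a hydroxymethyl group.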